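A few compounds are considered here, and "the series" means these few. Any claim that something is new, unique, unknown or untested is made for them only; others in the source may bear on it.

Compound 1 `O=C(NCc1ccc(Cl)cc1Cl)[C@@H]1CCC(=O)N1c1ccsc1`: 0.0417 h
Compound 2 `O=C(NCc1ccc(Cl)cc1Cl)[C@@H]1CCC(=O)N1c1ccoc1`: 0.0483 h

Both compounds were tested in an ADME assay on microsomes from liver (Homo sapiens) for metabolic stability, read by HPLC, with a stated time of 60 min, tested at 0.2 mg/mL; a higher number here means that the compound lasts longer, a lower number that the compound disappears faster. Compound 2, at 0.0483 h, stands level with compound 1 within the scatter of the measurement. Compound 3 `O=C(NCc1ccc(Cl)cc1Cl)[C@@H]1CCC(=O)N1c1nccs1` keeps the shared core and changes one group: 1,3-thiazol-2-yl in place of furan-3-yl on an amide-type nitrogen in a ring. Here 1,3-thiazol-2-yl comes in place of furan-3-yl on an amide-type nitrogen in a ring. Among the compounds with values here, only one measured step bears on this swap, a 1.2-fold higher number from compound 1 to compound 2 (0.06 log units; within the scatter), and it also exchanged one five-membered aromatic ring for another at the same place. Within the data shown here, that step was small, but no measured compound carries 1,3-thiazol-2-yl, so the guide is indirect. In this assay, no shift beyond the scatter is therefore expected. The expected change is a 1.1-fold higher number from compound 2 to compound 3 (0.06 log units; within the scatter). Compound 3 is estimated at 0.055 h, with an expected range from 0.028 h to 0.11 h.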

Compound 3, half-life: 0.125 h
Compound 3: middle estimate off by 2.3-fold (0.36 log units), on the low side, outside the stated range (above it).
By their numbers in this assay, from the lowest: compounds 1 and 2 (each within the scatter of the next); then compound 3.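

At this place, on an amide-type nitrogen in a ring, the two earlier rings gave no sign in this assay that the choice of five-membered aromatic ring mattered, but 1,3-thiazol-2-yl shows that it can: the swap from furan-3-yl gives a 2.6-fold higher number from compound 2 to compound 3 (0.41 log units; beyond the scatter) and the swap from thiophen-3-yl gives a 3.0-fold higher number from compound 1 to compound 3 (0.48 log units; beyond the scatter), both modest in size. Furan-3-yl and 1,3-thiazol-2-yl hold the same number of heavy atoms, so the count of heavy atoms alone does not separate them. Nothing measured here explains the difference.

Going by these compounds, it remains open whether a methyl group or an amine on the 1,3-thiazol-2-yl ring would keep this gain. On these data alone, it is also open whether the same swap would give a similar step with a different group on the far side of the amide.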